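Compound 4 and its expected paw edema inhibition

This account rests on a few compounds, and the source may have more. Where it says the series, first, only, none or still open, it means among the compounds named here.

Compound 3 `CCOC(=O)C1=C(C)NC(C)=C(C(=O)OCC)C1c1ccc(OCC(=O)NNC(=O)c2ccsc2Cl)cc1` gives 12.9% in a functional assay on the whole organism (strain Wistar) for inhibition, with Rattus norvegicus as the target, read by paw edema, with stated times of 30 min and 0.5 h, at a dose of 20 mg/kg (on this read-out higher numbers stand for more inhibition at the one dose given (going by the name of the read-out) and lower numbers for less inhibition), and stands second highest of the three measured numbers. Compound 1 `CCOC(=O)C1=C(C)NC(C)=C(C(=O)OCC)C1c1ccc(OCC(=O)NNC(=O)c2sccc2Cl)cc1` gives 10.6%, so that a number 2.3 percentage points higher from compound 1 to compound 3 (within the scatter). Compound 2 `CCOC(=O)C1=C(C)NC(C)=C(C(=O)OCC)C1c1ccc(OCC(=O)NNC(=O)c2cccs2)cc1` gives 44%, so that a number 31.1 percentage points lower from compound 2 to compound 3 (beyond the scatter). Compound 4 `CCOC(=O)C1=C(C)NC(C)=C(C(=O)OCC)C1c1ccc(OCc2nnc(S)o2)cc1` differs from compound 3 by a group of 6 heavy atoms (2 carbon, 2 nitrogen, 1 oxygen, 1 sulfur; one five-membered aromatic ring with 3 hetero atoms) in place of a group of 12 heavy atoms (6 carbon, 2 nitrogen, 2 oxygen, 1 sulfur, 1 chlorine; one five-membered aromatic ring with 1 hetero atom), on a saturated chain carbon bound to an oxygen on an aromatic ring. Going by the values given here, no measured step covers this exchange. Among the compounds with values here, the only guidance is that changes at the same end of the molecule moved the number beyond the scatter in a number 33.4 percentage points higher from compound 1 to compound 2 (beyond the scatter) and in a number 31.1 percentage points lower from compound 2 to compound 3 (beyond the scatter), while a number 2.3 percentage points higher from compound 1 to compound 3 (within the scatter) stayed within it, so a shift beyond the scatter in either direction is plausible and the estimate is correspondingly wide. Compound 4 is expected to give 22%, with a range from 5% to 45%. The expected step is a number 9.1 percentage points higher from compound 3 to compound 4 (within the scatter).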

Compound 4, a percentage reported as inhibition, in the whole organism at one dose (the size of the read-out at that dose, not a potency): 42.4%
Estimate against measurement, compound 4: 20.4 percentage points below; the measured number falls inside the stated range.
By their numbers in this assay, from the lowest: compounds 1 and 3 (each within the scatter of the next); then compounds 4 and 2 (each within the scatter of the next).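

In this assay, the small 5-sulfanyl-1,3,4-oxadiazol-2-yl group on the saturated chain carbon gives a number 1.6 percentage points lower from compound 2 to compound 4 (within the scatter) against the unchlorinated thiophene compound, so among these compounds the larger thiophene-bearing group is not needed to retain the read-out. Against the chlorothiophene compounds the same exchange gives a number 29.5 percentage points higher from compound 3 to compound 4 (beyond the scatter) and a number 31.8 percentage points higher from compound 1 to compound 4 (beyond the scatter) as its two steps. No measurement here bears on what lies behind these steps.

On these data alone, how an amine in place of the sulfanyl group of 5-sulfanyl-1,3,4-oxadiazol-2-yl would read remains open. So does a longer chain at this place.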